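Moving a Bromine Around a Ring in Two Cores

The compounds below may be only part of what the source reports. "The series", "measured", "known", "first", "only" and "open" are said of these compounds alone.

Compound 1 `COc1cccc(/C=C2\CCC/C(=C\c3ccccc3Br)C2=O)c1OC` and compound 2 `COc1cccc(/C=C2\CCC/C(=C\c3cccc(Br)c3)C2=O)c1OC` share one core and differ only by 3-bromophenyl in place of 2-bromophenyl on a double-bonded chain carbon bound to a double-bonded ring carbon. In a functional assay on MCF7 cells (Homo sapiens) for cytotoxicity, read by MTT assay, with a stated time of 72 h (on this read-out lower numbers stand for stronger inhibition and higher numbers for weaker inhibition), compound 1 gives 9700 nM, and compound 2 gives 11700 nM. The step of a 1.2-fold higher number from compound 1 to compound 2 (0.08 log units; within the scatter) shows that swapping one bromophenyl for the other left the read-out essentially unchanged on this core. Compound 3 `COc1ccc(/C=C2\CCC/C(=C\c3ccccc3Br)C2=O)cc1OC` carries the same 2-bromophenyl group as compound 1 but on a different core; the difference between the two cores is not broken down here. In this assay compound 3 gives 9500 nM, and the values of compound 1 and compound 3 show no separation beyond the scatter. Compound 4 `COc1ccc(/C=C2\CCC/C(=C\c3cccc(Br)c3)C2=O)cc1OC` is derived from compound 3 by the same change that turned compound 1 into compound 2: 3-bromophenyl in place of 2-bromophenyl on a double-bonded chain carbon bound to a double-bonded ring carbon. Because the earlier step of a 1.2-fold higher number from compound 1 to compound 2 (0.08 log units; within the scatter) stayed within the scatter, a similarly small step is expected here, a 1.2-fold higher number from compound 3 to compound 4 (0.08 log units; within the scatter). For compound 4 the estimated value in this assay is 11500 nM, with a likely range from 6000 nM to 22000 nM.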

Compound 4, half-maximal inhibitory concentration: 5300 nM
Beside the measured number, compound 4's estimate is 2.2-fold (0.34 log units) above it; the measured number lies below the stated range.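

On the core of compound 3, 3-bromophenyl in place of 2-bromophenyl gives a 1.8-fold lower number from compound 3 to compound 4 (0.25 log units; within the scatter), so on neither core does this swap stand out from the usual scatter of this assay. Set side by side, the two steps cannot be told apart: the same change on two cores in this assay, a 1.2-fold higher number (0.08 log units; within the scatter) from compound 1 to compound 2 and a 1.8-fold lower number (0.25 log units; within the scatter) from compound 3 to compound 4, 2.2-fold (0.33 log units) apart, within the scatter of two such steps. Among the compounds shown here, this shows that the change carried from one core to the other as a step too small to read, but it does not show that the two cores respond identically, nor that either bromophenyl group truly outperforms the other, and it rests on only two pairs of compounds.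

The compounds shown leave open what happens when the bromine on this ring is replaced by a different group, such as an amine or a carboxylic acid, which could produce a step large enough to read. They also leave open whether the same swap would stay this small in a cell line other than MCF7.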